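A few compounds are considered here, and "the series" means these few. Any claim that something is new, unique, unknown or untested is made for them only; others in the source may bear on it.

Measured in a physicochemical assay for solubility, read by HPLC, in phosphate buffer, measured as kinetic solubility, at pH 7.4; a higher number here means a more soluble compound, a lower number a less soluble compound:
compound 1 `CCOC(=O)c1cc(-c2ccc(F)cc2)n(-c2ccc(S(N)(=O)=O)cc2)c1`: 36400 nM
compound 2 `CCCC(=O)c1cc(-c2ccc(S(N)(=O)=O)cc2)n(-c2ccc(Cl)cc2)n1`: 25800 nM

Of the compounds shown here, two have been measured in this assay. Compound 2 has the lower of the two numbers, but the nearest neighbour, compound 1, lies within the usual scatter of it, so the two values show no real difference in this assay, and nothing more can be read from this pair. For the measured compounds named here, no step between measured compounds that differ in one place is available.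

The next compound, compound 3 `NS(=O)(=O)c1ccc(-c2cc(C(=O)N3CCCC3)nn2-c2ccc(Cl)cc2)cc1`, differs from compound 2 in one place:

pyrrolidin-1-yl in place of propyl on a carbonyl carbon

Going by the values given here, no measured pair shows this change, so its effect in this assay is not known from these data. The expectation is a small step, if any, toward a higher number, most likely not beyond the scatter of the measurement. On that basis the step from compound 2 to compound 3 is estimated as a 1.4-fold higher number from compound 2 to compound 3 (0.13 log units; within the scatter). For compound 3 the expected value in this assay is 35000 nM, with a range from 12000 nM to 100000 nM.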

Compound 3, solubility: 57900 nM
For compound 3 the middle estimate is 1.7-fold (0.22 log units) below the measured one; the measured number falls inside the stated range.
By their numbers in this assay, from the lowest: compounds 2, 1 and 3 (each within the scatter of the next, the first and the last beyond it).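

In this assay, for the compounds shown here, the change from propyl to pyrrolidin-1-yl on a carbonyl carbon gives a 2.2-fold higher number from compound 2 to compound 3 (0.35 log units; beyond the scatter), a modest step and the first between compounds that differ in one place. Compound 1 and compound 2 differ in more than one place and lie within the scatter of each other, so they could say nothing about any single position. This step shows that the group on this carbonyl carbon can move the number beyond the scatter, and that exchanging the open propyl chain for a five-membered non-aromatic ring with one nitrogen goes with a higher number, though nothing measured here accounts for the difference.

On these data alone, what remains open is whether the step follows the ring, the nitrogen or simply the larger group, as a single change at a single place cannot separate these. A dimethylamino group, which has the nitrogen without the ring, or a cyclopentyl group, which has a ring without the nitrogen, on the same carbonyl carbon would bear on that question directly.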